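A few compounds are considered here, and "the series" means these few. Any claim that something is new, unique, unknown or untested is made for them only; others in the source may bear on it.

Compound 1 `CC1=CCC2C(CC[C@@]2(C)O)C(C)(C)C1CC[C@@H]1[C@@]2(C)CCC(=O)C(C)(C)O[C@@H]2CC[C@]1(C)O`, compound 2 `CC1=CC[C@H]2[C@H](CC[C@]2(C)O)C(C)(C)[C@@H]1CC[C@H]1[C@]2(C)CC[C@H](OC(=O)c3ccccc3)C(C)(C)O[C@H]2CC[C@@]1(C)O` and compound 3 `COc1ccc(C(=O)O[C@H]2CC[C@]3(C)[C@H](CC[C@@](C)(O)[C@H]3CC[C@@H]3C(C)=CC[C@H]4[C@H](CC[C@]4(C)O)C3(C)C)OC2(C)C)cc1` share one core, as does the not yet measured compound 4 `CC1=CC[C@H]2[C@H](CC[C@]2(C)O)C(C)(C)[C@@H]1CC[C@H]1[C@]2(C)CC[C@H](OC(=O)c3ccco3)C(C)(C)O[C@H]2CC[C@@]1(C)O`. In a functional assay on MCF7 cells (Homo sapiens) for antiproliferative activity, read by MTT assay, with a stated time of 72 h (a higher number here means a weaker inhibitor, a lower number a stronger inhibitor), compound 1 gives only a limit, > 50000 nM. Compound 2 gives 21000 nM in this assay, and compound 3 gives 41700 nM. Of the two numbers shown, compound 3 holds the higher one, yet the single step with a number at both ends, a 2.0-fold higher number from compound 2 to compound 3 (0.30 log units; within the scatter), lies within the scatter.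

The step to compound 4 is furan-2-yl in place of 4-methoxyphenyl on a carbonyl carbon. Among the compounds with values here, the only measured step also altered the group attached to the carbonyl carbon and barely moved the number, and no measured step replaces the aromatic ring itself. On that footing the step of a 1.4-fold lower number from compound 3 to compound 4 (0.14 log units; within the scatter) is expected to stay within the scatter, with no clear direction. Compound 4 is therefore estimated at 30000 nM in this assay, with a range from 12000 nM to 80000 nM.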

Compound 4, half-maximal inhibitory concentration: 25700 nM
Beside the measured number, compound 4's estimate is 1.2-fold (0.07 log units) above it, within the range that was stated.
By their numbers in this assay, from the lowest: compounds 2, 4 and 3 (each within the scatter of the next). At a limit, above all of these: compound 1.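

Within the data shown here, the step of a 1.6-fold lower number from compound 3 to compound 4 (0.21 log units; within the scatter) and the step of a 1.2-fold higher number from compound 2 to compound 4 (0.09 log units; within the scatter) are the first to replace the aromatic ring itself, exchanging a six-membered aromatic ring of carbon only for a five-membered aromatic ring with 1 hetero atom. In this assay compounds 2, 3 and 4 therefore remain within the scatter of one another, so at this position neither of these ring changes moves the number measurably. Compound 1, which has no such ester group, gives a limit of the assay rather than a number: the limit of > 50000 nM in this assay, at which 1 of the 4 values shown sits.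

Still open, on these data alone, is whether a group without an aromatic ring on the carbonyl carbon, such as a short alkyl chain or cyclohexyl, would stay within that scatter. Equally open, as far as these compounds go, is what an amine on the aromatic ring or a pyridine ring in its place would do.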